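This account rests on a few compounds, and the source may have more. Where it says the series, first, only, none or still open, it means among the compounds named here.

Compound 1, `Cc1ccnc(/C(N)=N/NC(=S)N2CCOCC2)c1`, in a functional assay on HeLa cells (Homo sapiens) for cytotoxicity, read by MTT assay, with a stated time of 72 h, tested at 30 uM; on this read-out higher numbers stand for more inhibition of growth at the one concentration tested and lower numbers for less inhibition of growth: 45.2%
Compound 2, `N/C(=N\NC(=S)N1CCCCC1)c1ccccn1`, in this assay: 76.9%

Of the two numbers measured, compound 2 stands highest; its nearest neighbour, compound 1, gives a value that lies beyond the scatter below it. The two differ in two places at once, so neither change can be read off on its own.

Compound 3, `Cc1ccnc(/C(N)=N/NC(=S)N2CCCCC2)c1`, is not yet measured. It differs from compound 2 by methyl in place of hydrogen on an aromatic carbon. For the measured compounds named here, no pair of measured compounds differs only in this way, so there is no step to lean on. Compound 1 carries the same methyl group together with a different saturated ring and sits well below compound 2, which leaves the direction open.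

The expectation is a small change, a number 10.9 percentage points lower from compound 2 to compound 3 (beyond the scatter), downward if anything, possibly none beyond the scatter. Compound 3 is therefore estimated at 66%, within a range from 46% to 84%.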

Compound 3, percent growth inhibition at one concentration: 69.1%
Compound 3: middle estimate off by 3.1 percentage points, on the low side; measured number inside the range.
By their numbers in this assay, from the lowest: compound 1; then compounds 3 and 2 (each within the scatter of the next).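

In this assay methyl in place of hydrogen on this aromatic carbon, opposite the ring nitrogen, gives a number 7.8 percentage points lower from compound 2 to compound 3 (within the scatter) and so leaves growth inhibition unchanged as far as this read-out can tell. With that methyl present in both compounds, piperidin-1-yl in place of morpholin-4-yl on the thiocarbonyl carbon gives a number 23.9 percentage points higher from compound 1 to compound 3 (beyond the scatter) and is therefore the only one of these two single changes with a step beyond the scatter. No measurement here explains why either step has the size it does.

On these data alone, what an ethyl group, a methoxy group or a chlorine atom would do on this aromatic carbon stays open. So does whether methyl would have as little effect in a compound that carries morpholin-4-yl instead of piperidin-1-yl.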